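This account rests on a few compounds, and the source may have more. Where it says the series, first, only, none or still open, it means among the compounds named here.

Measured compounds:
compound 1 `COc1ccc(Cn2c(CCc3ccccc3)nnc2[C@H](NC(=O)c2ccccn2)c2c[nH]c3ccccc23)c(OC)c1` gives 25 nM in a functional assay on CHO cells for antagonist activity at growth hormone secretagogue receptor type 1 (Homo sapiens); on this read-out lower numbers stand for stronger inhibition and higher numbers for weaker inhibition
compound 2 `COc1ccc(Cn2c(CCc3ccccc3)nnc2[C@H](NC(=O)c2ccccn2)c2c[nH]c3ccccc23)cc1` gives 12 nM in this assay
compound 3 `COc1ccc(Cn2c(CCc3ccccc3)nnc2[C@H](NC(=O)c2cnccn2)c2c[nH]c3ccccc23)c(OC)c1` gives 24 nM in this assay

Compound 1 and compound 2 differ in one place: hydrogen in place of methoxy on an aromatic carbon. That change gave a 2.1-fold lower number from compound 1 to compound 2 (0.32 log units; beyond the scatter). Compound 1 and compound 3 differ in the amide part: pyrazin-2-yl in place of pyridin-2-yl on a carbonyl carbon. That exchange made a 1.0-fold lower number from compound 1 to compound 3 (0.02 log units; within the scatter), so compound 1 and compound 3 cannot be told apart on this read-out.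

Compound 4 `COc1ccc(Cn2c(CCc3ccccc3)nnc2[C@H](NC(=O)c2cnccn2)c2c[nH]c3ccccc23)cc1` has not been measured in this assay. It differs from compound 3 in one place: hydrogen in place of methoxy on an aromatic carbon. For the measured compounds named here, this is the same change as the one from compound 1 to compound 2; the two places are described in identical words, on an aromatic carbon of the six-membered ring of carbon only, ortho to a large group and meta to a methoxy group. The only difference between the two pairs is the core, which is pyrazin-2-yl in place of pyridin-2-yl on a carbonyl carbon, and that exchange left the number unchanged within the scatter.

Compound 4 is therefore expected to sit lower than compound 3 by about a 2.0-fold lower number from compound 3 to compound 4 (0.30 log units; within the scatter), resting on the step seen with a 2.1-fold lower number from compound 1 to compound 2 (0.32 log units; beyond the scatter) and on the near-identical values of compound 1 and compound 3. Going by the values given here, with only one prior example of the change, the expectation for compound 4 is put at 12 nM, with a range from 6 nM to 24 nM.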

Compound 4, antagonist equilibrium constant: 530 nM
Beside the measured number, compound 4's estimate is 44-fold (1.65 log units) below it; the measured number lies above the stated range.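

In this assay, the change from methoxy to hydrogen on the aromatic carbon does not carry over between the two amides: with the pyrazin-2-yl amide it gives a 22-fold higher number from compound 3 to compound 4 (1.34 log units; beyond the scatter), and the step differs in direction and size from the one with the pyridin-2-yl amide: the same change on two cores in this assay, a 2.1-fold lower number (0.32 log units; beyond the scatter) from compound 1 to compound 2 and a 22-fold higher number (1.34 log units; beyond the scatter) from compound 3 to compound 4, 46-fold (1.66 log units) apart, beyond the scatter of two such steps

Read along the other edge of the same four compounds, pyrazin-2-yl in place of pyridin-2-yl gives a 44-fold higher number from compound 2 to compound 4 (1.65 log units; beyond the scatter) with the 4-methoxybenzyl group, whereas with the 2,4-dimethoxybenzyl group the same exchange has no effect that can be told from the scatter: the same change on two cores in this assay, a 1.0-fold lower number (0.02 log units; within the scatter) from compound 1 to compound 3 and a 44-fold higher number (1.65 log units; beyond the scatter) from compound 2 to compound 4, 46-fold (1.66 log units) apart, beyond the scatter of two such steps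

The two changes are therefore not additive here, and neither can be transferred on the strength of its step in one setting, but this rests on a single set of four compounds, with compound 4 alone carrying the large shift, and it shows neither the reason for the shift nor how far it extends in the series.

Going by these compounds, whether the large step is peculiar to the pyrazin-2-yl amide stays open, since a phenyl or a pyrimidinyl group on the carbonyl carbon could be set against the 4-methoxybenzyl and 2,4-dimethoxybenzyl groups. Also open, on these data alone, is whether a fluorine or an ethoxy group in place of that methoxy would behave like hydrogen or like methoxy with the pyrazin-2-yl amide.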